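The source may report more compounds than this note shows. Statements on the series, on what has been measured and on what is new or still open speak of the compounds shown alone.

Of the compounds shown here, two have so far been tested in a functional assay on MT2 cells (Homo sapiens) for cytotoxicity, read by MTT assay; on this read-out higher numbers stand for lower toxicity in this test and lower numbers for higher toxicity in this test. Compound 1 `CC(C)=CCOc1cc(Nc2nccc(N)n2)ccc1Cl` gives 500 nM in this assay. Compound 2 `COc1cc(OC)nc(Nc2ccc(Cl)c(OCC=C(C)C)c2)n1` gives 28000 nM, the higher of the two numbers, so it is the less toxic of the pair here, and the gap to compound 1 is well beyond the usual scatter of repeated measurements. Compound 3 `COc1cc(N)nc(Nc2ccc(Cl)c(OCC=C(C)C)c2)n1` has not yet been measured. It differs from compound 2 in a single place: amino in place of methoxy on an aromatic carbon. This change brings the core of compound 3 closer to that of compound 1, and compound 1 shows a much lower number in this assay, at 500 nM, than compound 2 does. Going by the values given here, no measured pair isolates exactly this amino-for-methoxy exchange, so the direction can only be inferred from that resemblance. The number for compound 3 is therefore expected to come out around 10000 nM, within a range from 2500 nM to 40000 nM. This amounts to an expected downward step a 2.8-fold lower number from compound 2 to compound 3 (0.45 log units; beyond the scatter), of a size that may just reach beyond the scatter.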

Compound 3, half-maximal cytotoxic concentration: 19000 nM
Compound 3: middle estimate off by 1.9-fold (0.28 log units), on the low side, within the range that was stated.
By their numbers in this assay, from the lowest: compound 1; then compounds 3 and 2 (each within the scatter of the next).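

In this assay the exchange of methoxy for amino at this place, next to the ring nitrogen, amounts to a 1.5-fold lower number from compound 2 to compound 3 (0.17 log units; within the scatter) and so does not separate the two compounds, even though it brings in a hydrogen-bond donor. The large gap appears at a different change: compound 1 and compound 3 share the amino group and differ by methoxy in place of hydrogen on an aromatic carbon, a change that gives a 38-fold higher number from compound 1 to compound 3 (1.58 log units; beyond the scatter) on this read-out. Resembling compound 1 through the amino group is therefore not enough to bring compound 3 near the number of compound 1, and among these three compounds the high numbers belong to the two that carry a methoxy group at the place where compound 1 has hydrogen.

The data offer no measurement that explains why the step from hydrogen to methoxy is so large. From the compounds shown here alone, it remains open whether a smaller group such as fluorine, or a longer chain such as ethoxy, at that carbon would give a number closer to that of compound 1 or to that of compound 3.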